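Sulfamoyl for Nitro: Expected Tolerance in MT4 Cells

The source may report more compounds than this note shows. Statements on the series, on what has been measured and on what is new or still open speak of the compounds shown alone.

Of the compounds shown here, three built on one shared core have been tested in an ADME assay on MT4 cells (Homo sapiens) for cytotoxicity, read by MTT assay, with a stated time of 4 days; a higher number here means that more compound is tolerated, a lower number that less compound is tolerated. Compound 1 `CCOC(=O)c1cnc(N2CCN(Cc3ccc(C(F)(F)F)cc3)CC2)nc1Oc1c(C)cc(-c2ccc(C#N)cc2)cc1C` carries 4-(trifluoromethyl)phenyl on a saturated chain carbon bound to an amine nitrogen in a ring; in this assay compound 1 gives > 125000 nM, which is a limit of the assay rather than a number. Compound 2 `CCOC(=O)c1cnc(N2CCN(Cc3cccc(F)c3)CC2)nc1Oc1c(C)cc(-c2ccc(C#N)cc2)cc1C`, with 3-fluorophenyl in that place, gives in this assay > 125000 nM, again a limit. Compound 3 `CCOC(=O)c1cnc(N2CCN(Cc3ccc([N+](=O)[O-])cc3)CC2)nc1Oc1c(C)cc(-c2ccc(C#N)cc2)cc1C`, with 4-nitrophenyl there, gives > 125000 nM in this assay, also a limit. Because all three values sit at the limit of > 125000 nM in this assay, at which 3 of the 3 values shown sit, the steps a step that the two limits leave unreadable from compound 1 to compound 2, a step that the two limits leave unreadable from compound 1 to compound 3 and a step that the two limits leave unreadable from compound 2 to compound 3 cannot be read in size or direction. Compound 3 thus stands at the limit together with the other two, and no ordering among them can be drawn.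

Compound 4 `CCOC(=O)c1cnc(N2CCN(Cc3ccc(S(N)(=O)=O)cc3)CC2)nc1Oc1c(C)cc(-c2ccc(C#N)cc2)cc1C` differs from compound 3 by sulfamoyl in place of nitro on an aromatic carbon. Within the data shown here, no measured step shows how such a change behaves in this assay, and the three unreadable steps offer no direction. The expectation is that the step of a number no higher from compound 3 to compound 4 (the limit leaves the size open) stays within the scatter, with compound 4 again reaching the limit. Compound 4 is therefore expected to give about 125000 nM in this assay, within a range from 60000 nM to 250000 nM.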

Compound 4, half-maximal cytotoxic concentration: >= 7930 nM
Compound 4: only a limit was reported; the forecaster's own chance of this, stated with the estimate: 85%; the middle value is on the limit's open side.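

In this assay compound 4 gives >= 7930 nM, which is a limit and not a number. Among these compounds, compound 1, compound 2 and compound 3 also stand at a limit, so no step from any of them to compound 4 can be read. The compounds shown leave open where the true tolerated concentration of each lies, and whether sulfamoyl in place of nitro changes it at all.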